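A few compounds are considered here, and "the series" means these few. Any claim that something is new, unique, unknown or untested is made for them only; others in the source may bear on it.

Compound 1 `COc1cc(N)c(Cl)cc1NC(=O)C1CCN(Cc2ccc(Cl)cc2)CC1` in a functional assay on the whole organism for antagonist activity, with Mus musculus as the target (on this read-out lower numbers stand for an effect already at smaller amounts and higher numbers for an effect only at larger amounts of compound), gives 1.2 mg/kg. Compound 2 `COc1cc(N)c(Cl)cc1NC(=O)C1CCN(Cc2ccccc2F)CC1` in this assay gives no number but a limit, > 4 mg/kg. Going by the values given here, the single measured step, an at least 3.3-fold higher number from compound 1 to compound 2 (0.52 log units; beyond the scatter), is known only as a bound because of the limit of > 4 mg/kg in this assay, at which 1 of the 2 values shown sits. Compound 3 `CCCCCN1CCC(C(=O)Nc2cc(Cl)c(N)cc2OC)CC1` differs from compound 2 by butyl in place of 2-fluorophenyl on a saturated chain carbon bound to an amine nitrogen in a ring. Among the compounds with values here, no measured step bears directly on this exchange: the one step in the set swaps one aryl group for another on the same position, and it ends at a limit rather than a value, so it fixes only a floor for compound 2 in this assay and says nothing about a move from an aryl group to a chain. The expectation for compound 3 in this assay is therefore wide and is set at 5 mg/kg, between 1.5 mg/kg and 15 mg/kg. The step this estimate implies for compound 3, a step that the limit leaves unreadable from compound 2 to compound 3, is expected to stay within the scatter.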

Compound 3, dose for half-maximal effect: > 10 mg/kg
Compound 3 ended at the assay's limit; the forecaster's own chance of this, stated with the estimate: 45%; at least 2.0-fold (0.30 log units) between middle value and limit.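

Butyl in place of 4-chlorophenyl on a saturated chain carbon bound to an amine nitrogen in a ring gives an at least 8.3-fold higher number from compound 1 to compound 3 (0.92 log units; beyond the scatter) in this assay, so this position now has an exchange from an aryl group to an open chain, and that exchange also moves away from compound 1. Compound 3 gives only a limit, > 10 mg/kg, so the true size of this step is not known. The step from compound 2 to compound 3 cannot be read, and these notes therefore do not rank butyl against 2-fluorophenyl.

Open, from the compounds shown here alone, is whether a plain phenyl or a cyclohexyl at this position would stay close to compound 1 in this assay. Equally open, going by these compounds, is how a longer chain, or a chain ending in an amine, would read there.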